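Extending the chain from compound 2 to compound 3

The source may report more compounds than this note shows. Statements on the series, on what has been measured and on what is new or still open speak of the compounds shown alone.

Compound 1 `CCCCCCCCOP(=O)(O)OCCSC(=S)N1CCCC1`: > 100000 nM
Compound 2 `CCCOP(=O)(O)OCCSC(=S)N1CCCCC1`: > 100000 nM
Compound 3 `CCCCCCCCOP(=O)(O)OCCSC(=S)N1CCCCC1`: not yet measured

In a functional assay on PC-3 cells (Homo sapiens) for inhibition, read by MTT assay, with stated times of 18 h and 4 h (a higher number here means a weaker inhibitor, a lower number a stronger inhibitor), compound 2 gives > 100000 nM, which is a limit of the assay and not a number. Compound 1 gives > 100000 nM, also a limit. Both compounds therefore sit at the limit of > 100000 nM in this assay, at which 2 of the 2 values shown sit.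

Compound 3 differs from compound 2 by pentyl in place of hydrogen on a saturated chain carbon, three bonds along the chain from an oxygen on an unsaturated carbon, which also reads as propyl to octyl.

Compound 1 already carries octyl and still shows > 100000 nM, so no step beyond the scatter is expected in this assay. The expected change is a number no higher from compound 2 to compound 3 (the limit leaves the size open). The estimate for compound 3 is 100000 nM, with an expected range of 40000 nM to 200000 nM.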

Compound 3, half-maximal inhibitory concentration: > 100000 nM
Compound 3 ended at the assay's limit; the forecaster's own chance of this, stated with the estimate: 80%; the middle value sits exactly at the limit.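

In this assay compound 3 gives > 100000 nM as a limit of the assay. Within the data shown here, no step from compound 1 or compound 2 to compound 3 can be read. The compounds shown leave open which change to the shared core, if any, would give a value that is a number and not a limit.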